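Swapping an Aryl Amide for a Carboxylic Acid Side Chain

The source may report more compounds than this note shows. Statements on the series, on what has been measured and on what is new or still open speak of the compounds shown alone.

Of the compounds shown here, three built on one shared core have been tested in a functional assay on PC-3 cells (Homo sapiens) for antiproliferative activity, read by MTT assay, with a stated time of 48 h; a higher number here means a weaker inhibitor, a lower number a stronger inhibitor. Compound 1 `C#CCCOC(=O)c1ccc(C(CC)(CC)c2ccc(OCCC(O)(CC)CC)c(C)c2)n1CC` is an ester; in this assay compound 1 gives > 50000 nM, which is a limit of the assay rather than a number. Compound 2 `CCn1c(C(=O)Nc2ccc(OC(F)(F)F)cc2)ccc1C(CC)(CC)c1ccc(OCCC(O)(CC)CC)c(C)c1` is an amide; in this assay compound 2 gives > 50000 nM, again only a limit. Compound 3 `CCOc1ccc(NC(=O)c2ccc(C(CC)(CC)c3ccc(OCCC(O)(CC)CC)c(C)c3)n2CC)cc1` is a closely related amide; in this assay compound 3 gives > 50000 nM, also a limit. All three therefore sit at the limit of > 50000 nM in this assay, at which 3 of the 3 values shown sit, so the steps between them are a step that the two limits leave unreadable from compound 1 to compound 2, a step that the two limits leave unreadable from compound 1 to compound 3 and a step that the two limits leave unreadable from compound 2 to compound 3.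

Compound 4 `CCn1c(C(=O)NC(C)C(=O)O)ccc1C(CC)(CC)c1ccc(OCCC(O)(CC)CC)c(C)c1` differs from compound 2 by 1-carboxyethyl in place of 4-(trifluoromethoxy)phenyl on an amide-type nitrogen. For the measured compounds named here, no measured step bears on this change: none of the tested compounds carries the group that enters, and every measured step is unreadable. Compound 2 stands only at a limit, so no direction can be read from it. Compound 4 is therefore expected to show an estimated step that the limit leaves unreadable from compound 2 to compound 4. Compound 4 is expected to give about 80000 nM, with a range from 20000 nM to 300000 nM, most likely reported again as a limit.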

Compound 4, half-maximal inhibitory concentration: 11700 nM
Estimate against measurement, compound 4: 6.8-fold (0.83 log units) above; the whole stated range lies above it.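

In this assay, 1-carboxyethyl on the amide-type nitrogen gives a readable result where the aryl groups did not, with an at least 4.2-fold lower number from compound 2 to compound 4 (0.63 log units; beyond the scatter) and an at least 4.2-fold lower number from compound 3 to compound 4 (0.63 log units; beyond the scatter). The comparison with the ester, a change on the carbonyl carbon, points the same way, with an at least 4.2-fold lower number from compound 1 to compound 4 (0.63 log units; beyond the scatter). The steps among the earlier compounds cannot be read, so this is the only change shown that moves a compound off the limit: the limit of > 50000 nM in this assay, at which 3 of the 4 values shown sit.

The compounds shown cannot separate the loss of the aromatic ring from the arrival of the carboxylic acid, and a methyl ester of the 1-carboxyethyl group or a plain ethyl group on the same nitrogen would bear on that. They also leave open whether the methyl branch of 1-carboxyethyl matters, which a carboxymethyl group would test.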